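A few compounds are considered here, and "the series" means these few. Any claim that something is new, unique, unknown or untested is made for them only; others in the source may bear on it.

Compound 1 `COc1ccc(-c2ccc(-c3ccc(C(=N)N)o3)o2)cc1`: 1900 nM
Compound 2 `COc1cc(OC)cc(-c2ccc(-c3ccc(C(=N)N)o3)o2)c1`: 2350 nM
Compound 3 `N=C(N)c1ccc(-c2ccc(-c3ccc4ccccc4c3)s2)s1`: 1850 nM

Of the compounds shown here, three have been measured in a functional assay on MDA-MB-231 cells (Homo sapiens) for inhibition, read by sulforhodamine B assay, with a stated time of 48 h; on this read-out lower numbers stand for stronger inhibition of growth and higher numbers for weaker inhibition of growth. In this assay compound 1 gives 1900 nM, compound 2 gives 2350 nM and compound 3 gives 1850 nM. Compound 1 holds the second highest of the three numbers, but the gaps to its neighbours are small: the nearest is compound 3, the furthest is compound 2, and both lie within the scatter of repeated measurements, so the three values cannot be told apart.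

The step under consideration leads from compound 1 to compound 4 `N=C(N)c1ccc(-c2ccc(-c3ccc(F)cc3)o2)o1`, which has not yet been measured in this assay. The difference between the two structures is fluoro in place of methoxy on an aromatic carbon.

Going by the values given here, no measured pair in this set shows the same change, so there is no direct precedent for its size. Given that the three measured compounds, with different substituents on the same core, all sit within the scatter of one another, compound 4 is expected to give a similar value. The step from compound 1 to compound 4 is estimated as a 1.1-fold higher number from compound 1 to compound 4 (0.02 log units; within the scatter), that is, no change beyond the scatter. Compound 4 is estimated at 2000 nM, with a range from 700 nM to 6000 nM.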

Compound 4, concentration for 50% growth inhibition: 1570 nM
Compound 4: the middle estimate sits 1.3-fold (0.11 log units) above what was measured; the range from low to high includes it.
By their numbers in this assay, from the lowest: compounds 4, 3, 1 and 2 (each within the scatter of the next).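

In this assay, going by these compounds alone, the replacement of methoxy by fluoro on the aromatic carbon para to a large group gives the first comparison in this set of compounds that differ in one place, and it reads as a 1.2-fold lower number from compound 1 to compound 4 (0.08 log units; within the scatter) with no change beyond the scatter. At this position, then, the methoxy can give way to a fluoro, with one heavy atom fewer and one hydrogen-bond acceptor fewer by the count for the two groups, and growth inhibition stays indistinguishable from that of compound 1, so a methoxy is not needed here for a value of this size. Nothing in the available data bears on why the two groups read alike.

As far as these compounds go, with only methoxy and fluoro compared at this place, it remains open whether an amine, a carboxylic acid or a longer chain such as butoxy would also stay within the scatter or would move the number clearly. From the compounds shown here alone, it is also open whether fluoro in place of methoxy would give a step of similar size on compound 2, which carries two methoxy groups.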